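This account rests on a few compounds, and the source may have more. Where it says the series, first, only, none or still open, it means among the compounds named here.

Working notes on the urea series. Compound 1 `CN(C)c1ccc(NC(=O)Nc2cccc(CNc3nccnc3Cl)c2)cc1` in a functional assay on HepG2 cells (Homo sapiens) for antiproliferative activity, read by MTT assay, with a stated time of 48 h (on this read-out higher numbers stand for weaker inhibition and lower numbers for stronger inhibition), reaches only a limit, > 40000 nM; this value is the limit of the assay the limit of > 40000 nM in this assay, at which 1 of the 2 values shown sits, and not a number, so compound 1 stands at the weak end of what this assay can report. Compound 2 `O=C(Nc1cccc(CNc2nccnc2Cl)c1)NC1CCCC1` in this assay gives 18400 nM. Among the compounds with values here, the single measured step in the set, an at least 2.1-fold lower number from compound 1 to compound 2 (0.33 log units; beyond the scatter), replaces the aryl group on the urea nitrogen with a saturated ring and moves the read-out from the limit to a number.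

Compound 3 `Cc1ccc(NC(=O)Nc2cccc(CNc3nccnc3Cl)c2)cc1Cl` differs from compound 1 by 3-chloro-4-methylphenyl in place of 4-(dimethylamino)phenyl on an amide-type nitrogen. Within the data shown here, no measured step exchanges one aryl group for another at this nitrogen, so the only calibration is the step to compound 2, which shows that a change at this position can shift the number by at least a modest amount. The step from compound 1 to compound 3 is therefore expected to be modest, more likely toward a lower number than toward a higher one, with a real chance that the assay again reports only a limit. Compound 3 is estimated at 15000 nM, within a range of 4000 nM to 60000 nM. This estimate implies an expected step of an at least 2.6-fold lower number from compound 1 to compound 3 (0.42 log units; beyond the scatter) in this assay.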

Compound 3, half-maximal inhibitory concentration: 11300 nM
Compound 3: middle estimate off by 1.3-fold (0.12 log units), on the high side; the measured number falls inside the stated range.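

In this assay, an aryl group on an amide-type nitrogen does not by itself hold the read-out at the limit: 3-chloro-4-methylphenyl in place of 4-(dimethylamino)phenyl gives an at least 3.5-fold lower number from compound 1 to compound 3 (0.54 log units; beyond the scatter). The earlier step could not separate the loss of 4-(dimethylamino)phenyl from the loss of an aryl group, since it replaced one with cyclopentyl; this change keeps an aryl group and still moves the read-out from the limit to a number. The aryl group and the saturated ring cannot be told apart at this position, with 3-chloro-4-methylphenyl in place of cyclopentyl giving a 1.6-fold lower number from compound 2 to compound 3 (0.21 log units; within the scatter).

On these data alone, the full size of the change from 4-(dimethylamino)phenyl remains open because compound 1 is held only by a limit of the assay: the limit of > 40000 nM in this assay, at which 1 of the 3 values shown sits. Also open is whether the chlorine or the methyl on the phenyl ring matters on its own, and how an unsubstituted phenyl, a phenyl carrying a carboxylic acid or a longer alkyl chain on this nitrogen would read.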